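This account rests on a few compounds, and the source may have more. Where it says the series, first, only, none or still open, it means among the compounds named here.

Compound 1, `Clc1cc(N2CC[C@H]3CN[C@H]3C2)cnc1Cl`, is an agonist in a functional assay on HEK293 cells for agonist activity at Neuronal acetylcholine receptor; alpha3/beta4 (Homo sapiens), read by FLIPR (a higher number here means that more compound is needed for the effect, a lower number that less compound is needed), where compound 1 gives 9.9 nM. Compound 2, `Cc1cc(N2CC[C@H]3CN[C@H]3C2)cnc1Cl`, gives 7.2 nM in this assay; the change between the two, (methyl in place of chloro on an aromatic carbon), made a 1.4-fold lower number from compound 1 to compound 2 (0.14 log units; within the scatter). Compound 3, `Clc1cc(N2C[C@@H]3CCNC[C@@H]32)cnc1Cl`, has the same atoms as compound 1 joined differently; the difference between the two cores is not broken down here. In this assay compound 3 gives 4110 nM, the highest of the three numbers and far from those of compound 1 and compound 2. Compound 4, `Cc1cc(N2C[C@@H]3CCNC[C@@H]32)cnc1Cl`, carries the same change on the core of compound 3: methyl in place of chloro on an aromatic carbon. The earlier step of a 1.4-fold lower number from compound 1 to compound 2 (0.14 log units; within the scatter) stayed within the scatter. On that basis a step of similar size is expected for the same change on the second core, a 1.4-fold lower number from compound 3 to compound 4 (0.14 log units; within the scatter). Compound 4 is therefore estimated at 3000 nM, between 1400 nM and 6500 nM.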

Compound 4, half-maximal effective concentration: 1910 nM
Compound 4: middle estimate off by 1.6-fold (0.20 log units), on the high side; measured number inside the range.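

In this assay, methyl in place of chloro on an aromatic carbon gave a 2.2-fold lower number from compound 3 to compound 4 (0.33 log units; beyond the scatter). Set beside the earlier step on the other core, this step does not differ from it beyond the scatter: the same change on two cores in this assay, a 1.4-fold lower number (0.14 log units; within the scatter) from compound 1 to compound 2 and a 2.2-fold lower number (0.33 log units; beyond the scatter) from compound 3 to compound 4, 1.6-fold (0.19 log units) apart, within the scatter of two such steps. On these two cores the change therefore carries over at a similar size, but this rests on one pair per core, says nothing about other cores or other changes, and does not explain why the numbers on the core of compound 3 stand so far above those on the core of compound 1.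

The compounds shown leave open how other groups at this place, such as a methoxy, a nitrile, an amine or a longer chain, would fare on either core. They also leave open whether such groups would carry over between the cores as closely as methyl and chloro do.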